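A few compounds are considered here, and "the series" means these few. Any claim that something is new, unique, unknown or untested is made for them only; others in the source may bear on it.

Compound 1 `C=CC(=O)Nc1nc(-c2ccccc2)cs1`: 6600 nM
Compound 2 `C=CC(=O)N(CC(=O)OC(C)(C)C)c1nc(-c2ccccc2)cs1`: > 30000 nM (a limit of the assay, not a number)
Compound 3 `C=CC(=O)N(Cc1cc(C)no1)c1nc(-c2ccccc2)cs1`: not yet measured

In a functional assay on HT-29 cells (Homo sapiens) for antiproliferative activity, read by MTT assay, with a stated time of 72 h (on this read-out lower numbers stand for stronger inhibition and higher numbers for weaker inhibition), compound 2 gives only a limit, > 30000 nM, and no exact number. Compound 3 has 3-methyl-1,2-oxazol-5-yl in place of tert-butoxycarbonyl on a saturated chain carbon bound to an amide-type nitrogen. Among the measured compounds shown here, no measured step covers this exchange itself. The nearest is an at least 4.5-fold higher number from compound 1 to compound 2 (0.65 log units; beyond the scatter), a step beyond the scatter that put (tert-butoxycarbonyl)methyl in place of hydrogen on the amide-type nitrogen. Compound 3 also has a group in place of that hydrogen, so it is expected to stay weak in this assay, near compound 2 rather than compound 1. The expected change is a number no higher from compound 2 to compound 3 (the limit leaves the size open), with no step beyond the scatter foreseen. Compound 3 is estimated at 30000 nM, within a range of 12000 nM to 60000 nM.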

Compound 3, half-maximal inhibitory concentration: > 30000 nM
Compound 3 ended at the assay's limit (the forecaster's own chance of this, stated with the estimate: 55%); the middle value sits exactly at the limit.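

In this assay, putting (3-methyl-1,2-oxazol-5-yl)methyl in place of the amide hydrogen gives an at least 4.5-fold higher number from compound 1 to compound 3 (0.65 log units; beyond the scatter). The loss seen with (tert-butoxycarbonyl)methyl is therefore not tied to that one group: both groups on this nitrogen leave the number well short of the activity of the parent with the free amide hydrogen, and no compound shown goes against this. Compound 2 and compound 3 cannot be ranked against each other, and the step between them cannot be read, as what stands in the way is a limit of the assay and not a measured number: the limit of > 30000 nM in this assay, at which 2 of the 3 values shown sit.

On these data alone, whether a small group such as methyl on this nitrogen keeps any of the activity of compound 1 stays open. So does whether a chain ending in an amine or a carboxylic acid would give a readable number.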